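A few compounds are considered here, and "the series" means these few. Any claim that something is new, unique, unknown or untested is made for them only; others in the source may bear on it.

Two compounds carry numbers in an assay on Sf21 cells for inhibition of mitogen-activated protein kinase kinase kinase kinase 4 (Homo sapiens), read by ADP-Glo, with stated times of 30 min and 90 min (a lower number here means a stronger inhibitor, a higher number a weaker inhibitor), so far. Compound 1 `CC(C)NC(=O)c1ccc(-c2cnc(N)c(-c3ccc(C#N)cc3)c2)cc1` gives 12.6 nM in this assay. Compound 2 `Nc1ncc(Br)c2ccc(-c3ccnc(F)c3)nc12` gives 31.6 nM in this assay. Compound 2 thus stands at the higher of the two numbers, and its gap to compound 1 is wider than the usual scatter of repeated measurements. Compound 3 `CC(C)(O)c1cnc(N)c2nc(-c3ccnc(F)c3)ccc12` is not yet measured; it differs from compound 2 in one place: 1-hydroxy-1-methylethyl in place of bromo on an aromatic carbon. Going by the values given here, no measured pair shows this same change, so there is no measured step to lean on, and the two values at hand say nothing about it. Without such a step, the expected step for this change is small, if any, towards a lower number, not clearly beyond the scatter: the estimated step is a 1.6-fold lower number from compound 2 to compound 3 (0.20 log units; within the scatter). For compound 3 the estimate in this assay is 20 nM, with a range from 6 nM to 70 nM.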

Compound 3, half-maximal inhibitory concentration: 158 nM
Compound 3: the middle estimate sits 7.9-fold (0.90 log units) below what was measured, and the stated range ends below it.
By their numbers in this assay, from the lowest: compound 1; then compound 2; then compound 3.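

In this assay, going by these compounds alone, 1-hydroxy-1-methylethyl in place of bromo gives a 5.0-fold higher number from compound 2 to compound 3 (0.70 log units; beyond the scatter), the only measured step, so this aromatic carbon, para to an amino group, does not tolerate every change without a shift in the number. The entering group brings 4 heavy atoms, 1 hydrogen-bond donor and 1 hydrogen-bond acceptor where bromo brought 1 heavy atom and neither, and this single step cannot separate those differences. Nothing at hand gives a reason for the step.

Going by these compounds, whether methoxy, an amine or an isopropyl group without the hydroxyl would sit nearer bromo or nearer 1-hydroxy-1-methylethyl stays open. Also open, on these data alone, is whether the same change would give a similar step on the core of compound 1.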